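Swapping the Benzyl Ether Substituent in an Acylthiourea Pair

A few compounds are considered here, and "the series" means these few. Any claim that something is new, unique, unknown or untested is made for them only; others in the source may bear on it.

Two compounds built on the same core were tested in a functional assay on MNK45 cells (Homo sapiens) for inhibition, read by MTT assay, with a stated time of 48 h; on this read-out lower numbers stand for stronger inhibition and higher numbers for weaker inhibition. Compound 1 `Cc1ccc(NC(=S)NC(=O)c2ccc(OCc3ccc(Cl)c(Cl)c3)cc2)cc1-c1nc2ccccc2[nH]1` gives 8410 nM in this assay. Compound 2 `O=C(NC(=S)Nc1ccc(Cl)c(-c2nc3ccccc3[nH]2)c1)c1ccc(OCc2ccc(C(F)(F)F)cc2)cc1` gives 7830 nM in this assay, the lowest of the two numbers, though its nearest neighbour, compound 1, is within the scatter of it, so the two values cannot be ordered.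

Compound 3 `O=C(NC(=S)Nc1ccc(Cl)c(-c2nc3ccccc3[nH]2)c1)c1ccc(OCc2ccc(Cl)c(Cl)c2)cc1` is the untested member of the pair. It differs from compound 2 in one place: 3,4-dichlorophenyl in place of 4-(trifluoromethyl)phenyl on a saturated chain carbon bound to an oxygen on an aromatic ring. The same 3,4-dichlorobenzyl group is already present in compound 1, where it sits on a differently substituted core and gives a number indistinguishable from that of compound 2.

Going by the values given here, no step between measured compounds is available to size this change directly. On the two values shown, the step from compound 2 to compound 3 is expected to be small, of the order of a 1.1-fold lower number from compound 2 to compound 3 (0.05 log units; within the scatter), with no direction beyond the scatter. Compound 3 is therefore estimated at 7000 nM in this assay, with a likely range from 3000 nM to 16000 nM.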

Compound 3, half-maximal inhibitory concentration: 4600 nM
For compound 3 the middle estimate is 1.5-fold (0.18 log units) above the measured one, and the stated range covers the measured number.
By their numbers in this assay, from the lowest: compounds 3, 2 and 1 (each within the scatter of the next).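

In this assay, putting 3,4-dichlorophenyl in place of 4-(trifluoromethyl)phenyl on a saturated chain carbon bound to an oxygen on an aromatic ring gives a 1.7-fold lower number from compound 2 to compound 3 (0.23 log units; within the scatter), so this place accepts the exchange with no difference that can be told from the usual variation between repeats. Going by these compounds alone, compound 3 also gives the first comparison with compound 1 that differs in one place: chloro in place of methyl on an aromatic carbon gives a 1.8-fold lower number from compound 1 to compound 3 (0.26 log units; within the scatter), so that exchange on the core cannot be read as a real difference either. No accompanying measurement bears on this result.

The compounds shown leave open whether any group at this place can move the number beyond the scatter, for example an amine or a carboxylic acid on the phenyl ring, or a longer chain in place of the single saturated chain carbon. They also leave open whether chloro and methyl on the core would compare in the same way with 4-(trifluoromethyl)benzyl on the oxygen, a comparison that would need the methyl compound carrying that group.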